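The source may report more compounds than this note shows. Statements on the series, on what has been measured and on what is new or still open speak of the compounds shown alone.

Compound 1 `COc1cc(OC)c(OC)cc1/C=C/COC(=O)/C=C/c1cc(OC)c(OC)c(OC)c1OC`: 75%
Compound 2 `COc1cc(OC)c(OC)cc1/C=C/COC(=O)/C=C/c1ccc(Br)cc1`: 100%
Compound 3 `COc1cc(OC)c(OC)cc1/C=C/COC(=O)/C=C/c1ccc(OC)c(OC)c1OC`: 100%

In a functional assay on the whole organism (strain Kunming) with Mus musculus as the target, with a stated time of 0.5 h, at a dose of 100 mg/kg by the intraperitoneal route (on this read-out higher numbers stand for a weaker effect at the one dose given and lower numbers for a stronger effect), compound 2 gives 100%. Compound 3 shows the same number at the digits printed, and compound 1 sits lower, a gap beyond the scatter. Compound 4 `COc1cccc(/C=C/C(=O)OC/C=C/c2cc(OC)c(OC)cc2OC)c1` is not yet measured. It differs from compound 2 by 3-methoxyphenyl in place of 4-bromophenyl on a double-bonded chain carbon bound to a double-bonded chain carbon. For the measured compounds named here, only one step between measured compounds is known, and it sits on the other ring of the shared core: a number 25 percentage points higher from compound 1 to compound 3 (beyond the scatter). That step does not touch the part of the molecule changed here. What bears more directly on the question is that compound 2 and compound 3, which carry quite different rings at this same place, give the same number in this assay. Going by the values given here, with no direct step to rely on, the expected step of a number 5 percentage points lower from compound 2 to compound 4 (within the scatter) is one within the scatter. Compound 4 is therefore estimated to give 95% in this assay, with a range from 75% to 100%.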

Compound 4, a percentage reported as activity, at one dose (the size of the read-out at that dose, not a potency): 100%
Compound 4: middle estimate off by 5 percentage points, on the low side, within the range that was stated.
By their numbers in this assay, from the lowest: compound 1; then compounds 2, 3 and 4 (each within the scatter of the next).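

In this assay, exchanging the one ring that differs gives no change at the digits printed from compound 2 to compound 4 (within the scatter). The entering ring differs in its substituent, with oxygen and one hydrogen-bond acceptor where the leaving ring has bromine and none, yet at this single dose the two compounds cannot be told apart. Nothing available explains why this exchange leaves the two compounds level.

As far as these compounds go, it remains open whether a phenyl ring carrying an amine or a carboxylic acid at this place would separate from compound 2 and compound 4. The same holds for a longer chain in place of the ring, and a single dose cannot show whether these compounds would differ at other doses.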